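The compounds below may be only part of what the source reports. "The series", "measured", "known", "first", "only" and "open" are said of these compounds alone.

Measured compounds:
- compound 1, `COc1ccc(Cc2nc(-c3cc(Br)c(OCCCN(C)C)c(Br)c3)c[nH]c2=O)cc1Br`: 46200 nM
- compound 2, `COc1ccc(Cc2nc(-c3cc(Br)c(OCCCN(C)C)c(Br)c3)cnc2Cl)cc1Br`: 87300 nM

In a functional assay on THP-1 cells (Homo sapiens) for inhibition, read by MTT assay, with a stated time of 24 h (on this read-out higher numbers stand for weaker inhibition and lower numbers for stronger inhibition), compound 1 gives 46200 nM, and compound 2 gives 87300 nM. The two numbers differ by less than the usual scatter of repeated measurements, so neither compound can be placed ahead of the other on this read-out; both sit at the weak end of what the assay reports as a number. Going by the values given here, no step between them is counted, since they differ in more than one place.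

Compound 3, `CNCCCOc1c(Br)cc(-c2c[nH]c(=O)c(Cc3ccc(OC)c(Br)c3)n2)cc1Br`, is not yet measured. Against compound 1 the difference is hydrogen in place of methyl on an amine nitrogen. Among the compounds with values here, nothing among the measured pairs shows what this change does, so the expectation rests on compound 1 alone. The step of a 1.0-fold lower number from compound 1 to compound 3 (0.00 log units; within the scatter) is expected to stay within the scatter, with no preferred direction. Compound 3 is estimated at 46000 nM, in the range 20000 nM to 110000 nM.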

Compound 3, half-maximal inhibitory concentration: 90700 nM
For compound 3 the middle estimate is 2.0-fold (0.29 log units) below the measured one; measured number inside the range.
By their numbers in this assay, from the lowest: compounds 1, 2 and 3 (each within the scatter of the next).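

In this assay, hydrogen in place of methyl on the amine nitrogen, dimethylamino to methylamino, gives a 2.0-fold higher number from compound 1 to compound 3 (0.29 log units; within the scatter). Going by these compounds alone, this is the first single-place step, and it shows that this amine nitrogen can carry hydrogen instead of one methyl with no difference that stands clear of the scatter, though it rests on one pair alone. No measurement at hand gives a reason for this step or bears on it further.

Still open, as far as these compounds go, is how a primary amine, with no methyl left on the nitrogen, or a morpholine in place of dimethylamino, would read on this chain. Also open, from the compounds shown here alone, is whether a longer chain carrying the same amine, or the same methyl-to-hydrogen change made on compound 2, would stay inside the scatter.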